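The source may hold more compounds than are shown below. What is called first, only, known or untested is meant among the compounds shown, and "the series" means these compounds.

Compound 3 `CCCN(CCC)c1ccc(NC(=O)c2cc(Cl)ccc2O)c(Cl)c1` gives the lowest number of the three in an ADME assay on A549 cells (Homo sapiens) for cytotoxicity, read by resazurin assay, with a stated time of 48 h (on this read-out lower numbers stand for higher toxicity in this test and higher numbers for lower toxicity in this test), namely 10700 nM. Compound 1 `CCCNc1ccc(NC(=O)c2cc(Cl)ccc2O)c(Cl)c1` gives 22500 nM and compound 2 `O=C(Nc1ccc(NC2CCCCC2)cc1Cl)c1cc(Cl)ccc1O` gives 68300 nM, so compound 3 is the most cytotoxic of the measured set. Compound 4 `O=C(Nc1ccc(NCc2ccncc2)cc1Cl)c1cc(Cl)ccc1O` carries ((pyridin-4-yl)methyl)amino in place of dipropylamino on an aromatic carbon. Two steps speak to this change: a 2.1-fold lower number from compound 1 to compound 3 (0.32 log units; beyond the scatter), and a 6.4-fold lower number from compound 2 to compound 3 (0.81 log units; beyond the scatter). Both show that a nitrogen bearing one hydrogen and one group gave a higher number than the dipropylamino nitrogen, so compound 4, which returns to a nitrogen with one hydrogen, is expected to give a higher number, a step of about a 2.8-fold higher number from compound 3 to compound 4 (0.45 log units; beyond the scatter). Compound 4 is therefore estimated at 30000 nM, with a range from 12000 nM to 80000 nM.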

Compound 4, half-maximal cytotoxic concentration: 65300 nM
For compound 4 the middle estimate is 2.2-fold (0.34 log units) below the measured one; the range from low to high includes it.
By their numbers in this assay, from the lowest: compound 3; then compound 1; then compounds 4 and 2 (each within the scatter of the next).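

In this assay, putting ((pyridin-4-yl)methyl)amino in place of dipropylamino gives a 6.1-fold higher number from compound 3 to compound 4 (0.79 log units; beyond the scatter). On a nitrogen that keeps its hydrogen, the (pyridin-4-yl)methyl and cyclohexyl groups cannot be told apart, with a 1.0-fold lower number from compound 2 to compound 4 (0.02 log units; within the scatter), whereas replacing the ethyl end of the propyl group with pyridin-4-yl gives a 2.9-fold higher number from compound 1 to compound 4 (0.46 log units; beyond the scatter). Among compound 1, compound 2 and compound 4, then, both ring-bearing groups give higher numbers than the open propyl chain.

Nothing shown explains these shifts. Going by these compounds, whether the pyridine nitrogen matters stays open, and a benzyl group on the same nitrogen would test it.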